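A few compounds are considered here, and "the series" means these few. Any claim that something is new, unique, unknown or untested is made for them only; others in the source may bear on it.

Measured in an ADME assay on cells (Macrophage) for cytotoxicity, read by resazurin assay, with a stated time of 48 h; a higher number here means that more compound is tolerated, a lower number that less compound is tolerated:
- Compound 1 `COc1ccc(-c2cc(-c3ccc(OCc4cn(Cc5ccccc5)nn4)cc3O)nc(N)n2)cc1`: 42700 nM
- Compound 2 `Nc1nc(-c2ccccc2)cc(-c2ccc(OCc3cn(Cc4ccc(Br)cc4)nn3)cc2O)n1`: > 100000 nM (a limit)

Compound 2 reads > 100000 nM, which is a limit of this assay and not a number. Its standing is therefore this: the limit of > 100000 nM in this assay, at which 1 of the 2 values shown sits. Among the measured compounds shown here, no step between measured compounds is available to set a size for the change ahead.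

Compound 3 `Nc1nc(-c2ccccc2)cc(-c2ccc(OCc3cn(Cc4ccccc4)nn3)cc2O)n1` has hydrogen in place of bromo on an aromatic carbon, para to a large group (hydrogen in place of bromo on an aromatic carbon). For the measured compounds named here, compound 1 gives 42700 nM, the only true number, and the expectation in this assay leans on that value. A modest move towards less compound tolerated is expected, and the estimated step is an at least 1.6-fold lower number from compound 2 to compound 3 (0.22 log units; that floor lies within the scatter). For compound 3 the expected value is 60000 nM, with an estimated range of 25000 nM to 130000 nM.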

Compound 3, half-maximal cytotoxic concentration: 76500 nM
The estimate for compound 3 lay 1.3-fold (0.11 log units) below the measured number; low and high end bracket the measured number.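

In this assay, removing bromo from the 4-bromobenzyl group, leaving benzyl, can be read only as a floor, an at least 1.3-fold lower number from compound 2 to compound 3 (0.11 log units; that floor lies within the scatter). As far as these compounds go, the reading of compound 2 is a limit and not a number, so the true size of this step stays unknown: the limit of > 100000 nM in this assay, at which 1 of the 3 values shown sits. Hydrogen in place of methoxy on an aromatic carbon gives the first step in the series between two true numbers, a 1.8-fold higher number from compound 1 to compound 3 (0.25 log units; within the scatter), so this change has no effect here that can be told apart from repeat measurement.

The compounds shown leave open how far compound 2 truly lies from compound 3. They also leave open whether an amine or a carboxylic acid in place of bromo or methoxy would shift the number beyond the scatter.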